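A few compounds are considered here, and "the series" means these few. Any claim that something is new, unique, unknown or untested is made for them only; others in the source may bear on it.

Compound 1 `COc1ccc(CN2C(=O)c3cccnc3C2=O)cc1OC`: > 100000 nM
Compound 2 `CC(C)c1cccc(C(C)C)c1N1C(=O)c2cccnc2C1=O`: 21000 nM

In an ADME assay on Vero cells (Chlorocebus sabaeus) for cytotoxicity (a higher number here means a weaker inhibitor, a lower number a stronger inhibitor), compound 1 gives > 100000 nM, which is a limit of the assay and not a number. Compound 1 thus stands at the limit of > 100000 nM in this assay, at which 1 of the 2 values shown sits. Compound 2 gives 21000 nM. The unmeasured compound 3 `COc1ccc(CN2C(=O)c3cccnc3C2=O)cc1` differs from compound 1 by hydrogen in place of methoxy on an aromatic carbon. For the measured compounds named here, no step between measured compounds is known here, so the step from compound 1 to compound 3 is expected to be a number no higher from compound 1 to compound 3 (the limit leaves the size open), most likely none beyond the scatter and quite possibly again only a limit. Compound 3 is therefore estimated at 100000 nM, within a range from 30000 nM to 300000 nM.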

Compound 3, half-maximal inhibitory concentration: > 100000 nM
Compound 3: no number, only a limit; the forecaster's own chance of this, stated with the estimate: 70%; the middle value sits exactly at the limit.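

For the compounds shown here, compound 1 and compound 3 both stand at a limit of the assay and not at a number, so no step between them can be read: the limit of > 100000 nM in this assay, at which 2 of the 3 values shown sit. In this assay the compounds shown leave open whether hydrogen in place of methoxy on an aromatic carbon changes the value at all.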